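A Larger Amide Substituent on a Weakly Cytotoxic Core

The compounds below may be only part of what the source reports. "The series", "measured", "known", "first", "only" and "open" are said of these compounds alone.

Compound 1 `CCN(CC)C(=O)c1ccc(-c2cc(-c3cc(OC)ccc3OC)no2)s1` is a weakly active compound. Going by the values given here, in a functional assay on A549 cells (Homo sapiens) for cytotoxicity, read by XTT assay, with a stated time of 72 h (on this read-out lower numbers stand for stronger inhibition and higher numbers for weaker inhibition), compound 1 gives 11000 nM, the only plain number among the two values shown. Compound 2 `O=C1C=CC(=O)C(c2cc(-c3ccc(C(=O)N4CCCCC4)s3)on2)=C1` shares the amide-bearing part of the core but carries a different ring on the other side. In this assay compound 2 reaches only a limit, > 30000 nM, so no number is known for it. Compound 2 thus stands at the limit of > 30000 nM in this assay, at which 1 of the 2 values shown sits. Compound 3 `COc1ccc(CN(C)C(=O)c2ccc(-c3cc(-c4cc(OC)ccc4OC)no3)s2)cc1` differs from compound 1 in one place: (4-methoxybenzyl)(methyl)amino in place of diethylamino on a carbonyl carbon. Among the compounds with values here, no pair of measured compounds shows the effect of such an exchange, so the size of the step is uncertain. The step of a 1.4-fold lower number from compound 1 to compound 3 (0.14 log units; within the scatter) is expected to stay close to the scatter, with at most a slight shift toward stronger inhibition. Compound 3 is therefore expected to give 8000 nM, within a range from 2500 nM to 25000 nM.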

Compound 3, half-maximal inhibitory concentration: > 30000 nM
Compound 3: no number, only a limit (the forecaster's own chance of this, stated with the estimate: 20%); middle value at least 3.7-fold (0.57 log units) from the limit.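

Going by these compounds alone, exchanging diethylamino for (4-methoxybenzyl)(methyl)amino on a carbonyl carbon gives an at least 2.7-fold higher number from compound 1 to compound 3 (0.43 log units; beyond the scatter), which is the first readable step at this position and shows that the core does not tolerate this larger group without a loss of inhibition. In this assay compound 3 reaches only a limit, > 30000 nM, so it has no plain number of its own. The step therefore gives only a smallest possible size, and the top of the measurable range now governs much of what can be read from this series: the limit of > 30000 nM in this assay, at which 2 of the 3 values shown sit.

The compounds shown do not tell whether the loss follows the benzyl ring or its methoxy group, which plain benzyl(methyl)amino could separate. As far as these compounds go, it also remains open whether a smaller group on this carbonyl carbon, such as dimethylamino, would strengthen or weaken inhibition relative to compound 1.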